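The compounds below may be only part of what the source reports. "The series", "measured", "known", "first", "only" and "open" are said of these compounds alone.

Compound 1 `O=S(=O)(Nc1ccc2oc(-c3ccccc3)nc2c1)c1cccc(F)c1` was tested in an assay on cells for inhibition of HSP60/HSP10 (Homo sapiens), with a stated time of 60 min; a lower number here means a stronger inhibitor, a higher number a weaker inhibitor. In this assay compound 1 gives only a limit, > 100000 nM, which is the limit of > 100000 nM in this assay, at which 1 of the 3 values shown sits. Two other compounds were also measured. Compound 2 `O=S(=O)(Nc1ccc(-c2nc3ccccc3o2)cc1)c1ccc(F)c(C(F)(F)F)c1` gives 28000 nM in this assay. Compound 3 `O=S(=O)(Nc1ccc(-c2nc3ccccc3o2)cc1)c1cccs1` gives 63000 nM in this assay. Neither of them differs from compound 1 in a single place, so their values say nothing direct about the change considered here. Compound 4 `O=S(=O)(Nc1ccc2oc(-c3ccccc3)nc2c1)c1ccc(O)cc1` is not yet measured. It differs from compound 1 in one place: 4-hydroxyphenyl in place of 3-fluorophenyl on a sulfonyl sulfur. Within the data shown here, no measured pair shows what such a change does, so the direction of the step is open. Compound 4 is expected to give about 70000 nM, within a range from 15000 nM to 300000 nM. The step expected from compound 1 to compound 4 is an at least 1.4-fold lower number from compound 1 to compound 4 (0.15 log units; that floor lies within the scatter), which may sit within the usual scatter.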

Compound 4, half-maximal inhibitory concentration: 88000 nM
Compound 4: middle estimate off by 1.3-fold (0.10 log units), on the low side; the range from low to high includes it.
By their numbers in this assay, from the lowest: compound 2; then compounds 3 and 4 (each within the scatter of the next). At a limit, above all of these: compound 1.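

On the sulfonyl sulfur, 4-hydroxyphenyl in place of 3-fluorophenyl gives a measured number on this core in this assay: compound 4 gives 88000 nM. Compound 1 gives only a limit, > 100000 nM. The change can be read only as an at least 1.1-fold lower number from compound 1 to compound 4 (0.05 log units; that floor lies within the scatter), because its starting value is a limit: the limit of > 100000 nM in this assay, at which 1 of the 4 values shown sits.

The compounds shown leave open whether gaining the hydroxyl or losing the fluorine matters more here, and how far the true step reaches. They also leave open what an amine or a carboxylic acid on this phenyl ring would do.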